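Longer Ether Arms on a Triazolopyrimidine Receptor Ligand

The source may report more compounds than this note shows. Statements on the series, on what has been measured and on what is new or still open speak of the compounds shown alone.

Of the compounds shown here, three sharing one core have been measured in an in vitro assay on 293-EBNA cells for binding affinity to corticotropin-releasing factor receptor 1 (Homo sapiens); a higher number here means a weaker inhibitor, a lower number a stronger inhibitor. Compound 1, `Cc1nc(N2CCCCC2)c2nnn(-c3ccc(C(C)C)cc3Br)c2n1`, gives 46 nM. Compound 2, `CCCCC(CC)Nc1nc(C)nc2c1nnn2-c1ccc(C(C)C)cc1Br`, gives 3.1 nM, and compound 3, `COCC(COC)Oc1nc(C)nc2c1nnn2-c1ccc(C(C)C)cc1Br`, gives 7.1 nM. Compound 3 therefore stands second highest of the three numbers: the step of a 2.3-fold higher number from compound 2 to compound 3 (0.36 log units; beyond the scatter) separates it from compound 2, and the step of a 6.5-fold lower number from compound 1 to compound 3 (0.81 log units; beyond the scatter) separates it from compound 1. The largest step among the measured compounds is a 15-fold lower number from compound 1 to compound 2 (1.17 log units; beyond the scatter).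

Compound 4, `CCOCC(COCC)Oc1nc(C)nc2c1nnn2-c1ccc(C(C)C)cc1Br`, differs from compound 3 only in that (2-ethoxy-1-(ethoxymethyl)ethyl in place of 2-methoxy-1-(methoxymethyl)ethyl on an oxygen on an aromatic ring). Within the data shown here, none of the measured steps changes the same part of the molecule in the same way: each of them exchanges the whole group on the aromatic carbon, while the move from compound 3 to compound 4 keeps the oxygen link and alters only the arms beyond it. The two measured compounds with open-chain groups, compound 2 and compound 3, both sit well below compound 1, so a long open chain on this position appears compatible with strong binding, but the data give no direct guide to how lengthening the ether arms acts.

The step from compound 3 to compound 4 in this assay is expected to be small, a 1.4-fold lower number from compound 3 to compound 4 (0.15 log units; within the scatter). Compound 4 is estimated at 5 nM, with a likely range from 2 nM to 15 nM.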

Compound 4, inhibition constant: 39.7 nM
Estimate against measurement, compound 4: 7.9-fold (0.90 log units) below, and the stated range ends below it.
By their numbers in this assay, from the lowest: compound 2; then compound 3; then compounds 4 and 1 (each within the scatter of the next).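

In this assay, the arms beyond the oxygen matter: 2-ethoxy-1-(ethoxymethyl)ethyl in place of 2-methoxy-1-(methoxymethyl)ethyl gives a 5.6-fold higher number from compound 3 to compound 4 (0.75 log units; beyond the scatter), even though the link to the aromatic ring stays the same and the number of hydrogen-bond acceptors does not change. An open chain at this place is therefore no assurance of strong binding, as the large step of a 13-fold higher number from compound 2 to compound 4 (1.11 log units; beyond the scatter) shows, while a 1.2-fold lower number from compound 1 to compound 4 (0.06 log units; within the scatter) leaves this open-chain ether and the ring-bearing piperidin-1-yl compound impossible to tell apart in this measurement. Nothing shown here gives a measured reason for the effect of the two ethyl ends.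

On these data alone, it remains open whether both arms must change, as a chain with one methoxy arm and one ethoxy arm would test, and whether propoxy arms would move the number further in the same direction. Also open, as far as these compounds go, is whether the same ethoxy arms would behave in the same way in this assay on an amine link in place of the oxygen.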